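From methyl to ethoxy on a carboxy compound

A few compounds are considered here, and "the series" means these few. Any claim that something is new, unique, unknown or untested is made for them only; others in the source may bear on it.

Measured so far:
- compound 1 `Cc1ccc2nc(C(=O)Nc3c(F)cc(-c4cccc(F)c4)cc3F)c(C)c(O)c2c1` gives 90500 nM
- compound 2 `Cc1c(C(=O)Nc2c(F)cc(-c3cccc(F)c3)cc2F)nc2ccc(OC(F)(F)F)cc2c1O` gives 38300 nM
- compound 3 `Cc1ccc2nc(C(=O)Nc3c(F)cc(-c4cccc(F)c4)cc3F)c(C)c(C(=O)O)c2c1` gives 26000 nM

All three were tested in a functional assay on A-375 cells (Homo sapiens) for antiproliferative activity, read by MTT assay, with a stated time of 24 h; on this read-out higher numbers stand for weaker inhibition and lower numbers for stronger inhibition. Compound 3 (26000 nM) and compound 2 (38300 nM) lie within the scatter of each other, so neither can be ranked above the other. Carboxy in place of hydroxy gave a 3.5-fold lower number from compound 1 to compound 3 (0.54 log units; beyond the scatter), a modest step.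

Compound 4 `CCOc1ccc2nc(C(=O)Nc3c(F)cc(-c4cccc(F)c4)cc3F)c(C)c(C(=O)O)c2c1` differs from compound 3 in one place: ethoxy in place of methyl on an aromatic carbon. In words, this is ethoxy in place of methyl on an aromatic carbon. For the measured compounds named here, no ethoxy compound has been measured. The closest guide is trifluoromethoxy in place of methyl on an aromatic carbon, which gave a 2.4-fold lower number from compound 1 to compound 2 (0.37 log units; beyond the scatter). That step involves a different group and a compound with hydroxy rather than carboxy, so it offers only rough support. A small move toward a lower number therefore seems likely, and it may not clear the scatter. The expected change is a 1.7-fold lower number from compound 3 to compound 4 (0.24 log units; within the scatter) in size. The estimated value for compound 4 is 15000 nM with an expected range of 5500 nM to 42000 nM in this assay once measured.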

Compound 4, half-maximal inhibitory concentration: 14900 nM
For compound 4 the middle estimate is 1.0-fold (0.00 log units) above the measured one, and the stated range covers the measured number.
By their numbers in this assay, from the lowest: compounds 4, 3 and 2 (each within the scatter of the next, the first and the last beyond it); then compound 1.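

In this assay, ethoxy in place of methyl on this aromatic carbon gave a 1.7-fold lower number from compound 3 to compound 4 (0.24 log units; within the scatter), so compound 3 and compound 4 cannot be ranked against each other. The new result shows that, on a carboxy compound, this position accepts ethoxy, with 3 heavy atoms where methyl has 1, without a change beyond the scatter; the earlier pair, compound 1 and compound 2, spoke only for trifluoromethoxy on a hydroxy compound. No measured evidence bears on why the step is this small.

Still open, as far as these compounds go, is whether a longer chain such as propoxy, or an amine, would be accepted at this carbon in the same way. Also open, from the compounds shown here alone, is whether ethoxy would give a similar step on compound 1, which carries hydroxy rather than carboxy.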